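Trimming 1H-benzimidazol-2-yl to 1H-imidazol-2-yl on sulfur

A few compounds are considered here, and "the series" means these few. Any claim that something is new, unique, unknown or untested is made for them only; others in the source may bear on it.

In a functional assay on U2OS cells (Homo sapiens) for antiproliferative activity, read by MTT assay, with a stated time of 72 h (on this read-out lower numbers stand for stronger inhibition and higher numbers for weaker inhibition), compound 1 `O=C(Cc1nnc(NC(=O)c2ccc(Cl)cc2)s1)N/N=C/c1ccc(O)cc1` gives > 100000 nM as a limit and not a number. Going by the values given here, compound 2 `O=C(CSc1nc2ccccc2[nH]1)Nc1ccc2nc(NC(=O)c3ccc(C(F)(F)F)cc3)sc2c1` at 7110 nM is therefore the only true number so far. Compound 3 `O=C(CSc1ncc[nH]1)Nc1ccc2nc(NC(=O)c3ccc(C(F)(F)F)cc3)sc2c1` differs from compound 2 by 1H-imidazol-2-yl in place of 1H-benzimidazol-2-yl on a sulfur with 1H-imidazol-2-yl in place of 1H-benzimidazol-2-yl on a sulfur. Among the compounds with values here, no measured step covers this change, so only a modest shift towards weaker inhibition is expected in this assay with a 2.1-fold higher number from compound 2 to compound 3 (0.32 log units; beyond the scatter) as the estimated size. The estimate for compound 3 is 15000 nM with an expected range of 5000 nM to 60000 nM for the coming measurement.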

Compound 3, half-maximal inhibitory concentration: 18800 nM
Beside the measured number, compound 3's estimate is 1.3-fold (0.10 log units) below it, and the stated range covers the measured number.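

In this assay, going by these compounds alone, the change from 1H-benzimidazol-2-yl to 1H-imidazol-2-yl on the sulfur gives a 2.6-fold higher number from compound 2 to compound 3 (0.42 log units; beyond the scatter) as the first measured step at this position. Losing the six-membered aromatic ring of carbon only therefore weakens inhibition, yet compound 3 still gives a true number and not a limit. The six-membered ring is thus not needed for a measurable value in this series.

From the compounds shown here alone, whether a phenyl group or an aliphatic amine on the sulfur would keep or lose inhibition stays open. No measurement shown gives a cause for this step.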